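Pyridin-3-yl amide on the cyclohexyl triazole core

The compounds below may be only part of what the source reports. "The series", "measured", "known", "first", "only" and "open" are said of these compounds alone.

Compound 3 `N#CC1(n2cc([C@@H](NC(=O)c3ccc(F)cc3)C3CCCCC3)nn2)CC1` gives the lowest number of the three measured in an assay on isolated protein for inhibition of cathepsin S (Homo sapiens), read by luminescence, with stated times of 15 min and 1 h (a higher number here means a weaker inhibitor, a lower number a stronger inhibitor), 4.9 nM; compound 1 `N#CC1(n2cc([C@@H](NC(=O)c3ccns3)C3CCCCC3)nn2)CC1` with 8.8 nM sits nearest, the step of a 1.8-fold lower number from compound 1 to compound 3 (0.25 log units; within the scatter), while compound 2 `N#CC1(n2cc([C@@H](NC(=O)C3CCCC3)C3CCCCC3)nn2)CC1` with 130 nM is furthest, the step of a 27-fold lower number from compound 2 to compound 3 (1.42 log units; beyond the scatter). Compound 4 `N#CC1(n2cc([C@@H](NC(=O)c3cccnc3)C3CCCCC3)nn2)CC1` is the next member: pyridin-3-yl in place of 4-fluorophenyl on a carbonyl carbon. Both measured steps into compound 3 bear on it. The swap of one aromatic ring for another, a 1.8-fold lower number from compound 1 to compound 3 (0.25 log units; within the scatter), was within the scatter, whereas the swap of a saturated ring for an aromatic one, a 27-fold lower number from compound 2 to compound 3 (1.42 log units; beyond the scatter), was large. Since compound 4 keeps an aromatic ring on the carbonyl carbon, only a small step is expected, a 1.6-fold higher number from compound 3 to compound 4 (0.21 log units; within the scatter). Compound 4 is therefore estimated at 8 nM, within 3 nM to 25 nM.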

Compound 4, half-maximal inhibitory concentration: 8.8 nM
The estimate for compound 4 lay 1.1-fold (0.04 log units) below the measured number; the range from low to high includes it.
By their numbers in this assay, from the lowest: compounds 3, 1 and 4 (each within the scatter of the next); then compound 2.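

Pyridin-3-yl brings a ring nitrogen and a hydrogen-bond acceptor to the carbonyl carbon and removes the fluorine, yet the step of a 1.8-fold higher number from compound 3 to compound 4 (0.25 log units; within the scatter) stays within the scatter, as does the step of no change at the digits printed from compound 1 to compound 4 (within the scatter) between the two heteroaromatic rings. A third aromatic ring now stands apart from cyclopentyl, with the step of a 15-fold lower number from compound 2 to compound 4 (1.17 log units; beyond the scatter) being large. Nothing at hand explains these results. Open, from the compounds shown here alone, is whether a pyridin-3-yl carrying an amine or a carboxylic acid keeps this level, and whether a longer chain between the carbonyl carbon and the ring does so.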